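Isopropyl on the nitrogen of compound 2

The source may report more compounds than this note shows. Statements on the series, on what has been measured and on what is new or still open speak of the compounds shown alone.

In a functional assay on brain (Rattus norvegicus, strain Wistar) for inhibition (on this read-out lower numbers stand for stronger inhibition and higher numbers for weaker inhibition), compound 1 `Cc1[nH]c(=O)n(C)c1-c1ccccc1` reports only a limit, > 100000 nM. Adding a butyl group gives compound 2 `CCCCc1ccc(-c2c(C)[nH]c(=O)n2C)cc1`, at 10700 nM, and the change amounts to an at least 9.3-fold lower number from compound 1 to compound 2 (0.97 log units; beyond the scatter). Compound 3 `CCCCc1ccc(-c2c(CC)[nH]c(=O)n2C)cc1` gives 13900 nM. Among the compounds with values here, these two are the only true numbers in the set, and they do not separate: the change is a 1.3-fold higher number from compound 2 to compound 3 (0.11 log units; within the scatter).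

Compound 4 `CCCCc1ccc(-c2c(C)[nH]c(=O)n2C(C)C)cc1` has yet to be measured. It differs from compound 2 by isopropyl in place of methyl on an aromatic nitrogen, next to the ring atom that bears a large group. Within the data shown here, no measured step touches that nitrogen, so the evidence is indirect. The closest guide is the added methyl of compound 3, which gave a 1.3-fold higher number from compound 2 to compound 3 (0.11 log units; within the scatter). A similarly small effect is therefore expected in this assay, with no shift beyond the scatter, though the uncertainty is wide. The expected change is a 1.2-fold higher number from compound 2 to compound 4 (0.08 log units; within the scatter). For compound 4 the estimated value is 13000 nM, with an expected range of 4000 nM to 45000 nM.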

Compound 4, half-maximal inhibitory concentration: 10700 nM
Compound 4: middle estimate off by 1.2-fold (0.08 log units), on the high side; measured number inside the range.
By their numbers in this assay, from the lowest: compounds 2, 4 and 3 (each within the scatter of the next). At a limit, above all of these: compound 1.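

Within the data shown here, compound 4 gives the first reading at this nitrogen, which no earlier step had touched: in this assay, isopropyl in place of methyl on an aromatic nitrogen brings no change at the digits printed from compound 2 to compound 4 (within the scatter). The isopropyl has 3 heavy atoms against 1 for the methyl, so this position, next to the ring atom that bears a large group, accepts a larger carbon group with no change that can be read. The enlargement at the other end of the ring gave a similar picture, with a 1.3-fold higher number from compound 2 to compound 3 (0.11 log units; within the scatter), so neither change moves the number beyond the scatter.

As far as these compounds go, compound 1, which lacks the butyl group, reports only a limit, so the same change cannot be read on that background: the limit of > 100000 nM in this assay, at which 1 of the 4 values shown sits. Also open is how this nitrogen would respond to an amine, a carboxylic acid or a longer chain in place of the isopropyl.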